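Oxazolylmethyl to pyridinylmethyl on a piperidine-ether series

The source may report more compounds than this note shows. Statements on the series, on what has been measured and on what is new or still open speak of the compounds shown alone.

Measured so far:
compound 1, `Clc1cc(Cl)cc(CO[C@H]2CCCN(Cc3ncco3)[C@H]2c2ccccc2)c1`: > 200000 nM (a limit, not a number)
compound 2, `COC(=O)Nn1c(C[C@H]2CCC[C@H](OCc3cc(C(F)(F)F)cc(C(F)(F)F)c3)[C@@H]2c2ccccc2)n[nH]c1=O`: 4500 nM
compound 3, `O=C(O)c1ccc2c(CN3CCC[C@H](O[C@H](CO)c4cc(Cl)cc(Cl)c4)[C@@H]3c3ccccc3)c[nH]c2c1`: 22000 nM

Three compounds of the series have been run in an assay on isolated protein for activation of cGMP-dependent protein kinase 1 (Homo sapiens), read by ADP-Glo, with stated times of 120 min and 40 min; on this read-out higher numbers stand for an effect only at larger amounts of compound and lower numbers for an effect already at smaller amounts. Compound 2 gives 4500 nM and compound 3 gives 22000 nM; the two differ in several places, so their gap is not traced to a single change. Compound 1 stands apart: in this assay compound 1 reports only > 200000 nM, which is a limit of the assay and not a number, as recorded in the limit of > 200000 nM in this assay, at which 1 of the 3 values shown sits. Among the compounds with values here, no two measured compounds differ in one place, so no measured step is available to lean on.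

The next compound, compound 4, `Clc1cc(Cl)cc(CO[C@H]2CCCN(Cc3ccncc3)[C@H]2c2ccccc2)c1`, differs from compound 1 in one place: pyridin-4-yl in place of 1,3-oxazol-2-yl on a saturated chain carbon bound to an amine nitrogen in a ring. With compound 1 sitting at the limit, the step from compound 1 to compound 4 cannot be read off as a measured quantity; the expectation rests on compound 1 alone. The working expectation is that the step of an at least 1.3-fold lower number from compound 1 to compound 4 (0.12 log units; that floor lies within the scatter) stays within the scatter, that is, no clear gain. Compound 4 is therefore estimated at 150000 nM, within a range of 30000 nM to 500000 nM, with a fair chance that this assay again reports only a limit.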

Compound 4, half-maximal effective concentration: > 200000 nM
Compound 4 ended at the assay's limit (the forecaster's own chance of this, stated with the estimate: 65%); at least 1.3-fold (0.12 log units) between middle value and limit.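

Within the data shown here, compound 1 and compound 4 both end at a limit of the assay rather than a number, so no step between them can be read: the limit of > 200000 nM in this assay, at which 2 of the 4 values shown sit. The compounds shown leave open whether pyridin-4-yl in place of 1,3-oxazol-2-yl changes the read-out at all.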